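Replacing the dimethylcarbamoyl group of compound 3

The source may hold more compounds than are shown below. What is called first, only, known or untested is meant among the compounds shown, and "the series" means these compounds.

Compound 1, `CCOc1ccc(-c2ccc(N(C[C@@H](N)[C@@H](C)CC)C(=O)[C@@H]3C[C@H]3c3ccccc3)cc2)cc1`: 90 nM
Compound 2, `CC[C@H](C)[C@H](N)CN(C(=O)[C@@H]1C[C@H]1c1ccccc1)c1ccc(-c2ccc(COC(C)(C)C)cc2)cc1`: 280 nM
Compound 3, `CC[C@H](C)[C@H](N)CN(C(=O)[C@@H]1C[C@H]1c1ccccc1)c1ccc(-c2ccc(C(=O)N(C)C)cc2)cc1`: 980 nM

All three compounds share one core and differ only in the group on the outer aromatic ring. In a functional assay for agonist activity at G protein-coupled receptor 88 (Homo sapiens), read by HTRF and cAMP accumulation (a lower number here means that less compound is needed, a higher number that more compound is needed for the effect), compound 1 gives 90 nM, compound 2 gives 280 nM and compound 3 gives 980 nM. Compound 3 stands at the highest of the three numbers: the step of a 3.5-fold higher number from compound 2 to compound 3 (0.54 log units; beyond the scatter) is modest, while the step of an 11-fold higher number from compound 1 to compound 3 (1.04 log units; beyond the scatter) is large, and both lie beyond the scatter.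

Compound 4, `CC[C@H](C)[C@H](N)CN(C(=O)[C@@H]1C[C@H]1c1ccccc1)c1ccc(-c2ccc(CNC)cc2)cc1`, has not yet been measured in this assay. Its change from compound 3 is (methylamino)methyl in place of dimethylcarbamoyl on an aromatic carbon.

Two of the measured steps bear on this change: an 11-fold higher number from compound 1 to compound 3 (1.04 log units; beyond the scatter) and a 3.5-fold higher number from compound 2 to compound 3 (0.54 log units; beyond the scatter) both end in the dimethylcarbamoyl group that now leaves, and both raised the number. Among the measured compounds shown here, no measured compound carries the entering (methylamino)methyl group, so its own effect is unknown. Because an 11-fold higher number from compound 1 to compound 3 (1.04 log units; beyond the scatter) and a 3.5-fold higher number from compound 2 to compound 3 (0.54 log units; beyond the scatter) were unfavourable, removing the dimethylcarbamoyl group is expected to bring a modest lower number, but with wide uncertainty. For compound 4 the expected step is a 2.5-fold lower number from compound 3 to compound 4 (0.39 log units; beyond the scatter). Compound 4 is therefore estimated at 400 nM, within 120 nM to 1500 nM.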

Compound 4, half-maximal effective concentration: 6400 nM
Beside the measured number, compound 4's estimate is 16-fold (1.20 log units) below it; measured number above the stated range.
By their numbers in this assay, from the lowest: compound 1; then compound 2; then compound 3; then compound 4.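

In this assay, removing the dimethylcarbamoyl group did not lower the number at this position on the outer ring: with (methylamino)methyl in its place the number rose further, a 6.5-fold higher number from compound 3 to compound 4 (0.81 log units; beyond the scatter), so dimethylcarbamoyl, the poorest of the three earlier groups, is not the poorest group this position can carry. The new group also falls well behind the two other groups, with a 23-fold higher number from compound 2 to compound 4 (1.36 log units; beyond the scatter), where methylamino stands in place of tert-butoxy on the same saturated carbon, and a 71-fold higher number from compound 1 to compound 4 (1.85 log units; beyond the scatter), which extends the order at this position to ethoxy, (tert-butoxy)methyl, dimethylcarbamoyl and then (methylamino)methyl. No measurement available here explains why the number rose.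

The compounds shown leave open whether the hydrogen-bond donor counted on the entering group goes with the higher number, since none of them carries a (dimethylamino)methyl group, which would keep the amine without that hydrogen. They also leave open how a longer alkoxy chain such as propoxy, or a neutral ether such as methoxymethyl, would compare with ethoxy at this position.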